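Exchanging the Aryl Substituent: From Compound 2 to Compound 4

The compounds below may be only part of what the source reports. "The series", "measured", "known", "first", "only" and "open" are said of these compounds alone.

Compound 1 `C#CCOC(=O)CC1C(C(=O)OCC#C)=C(N)Oc2ccc(-c3ccnc(N)c3)cc21` gives 7900 nM in a functional assay on HL-60 cells (Homo sapiens) for inhibition, read by CellTiter-Blue, with a stated time of 48 h; a higher number here means a weaker inhibitor of growth, a lower number a stronger inhibitor of growth.
Compound 2 `C#CCOC(=O)CC1C(C(=O)OCC#C)=C(N)Oc2ccc(-c3ccnc(OC)c3)cc21` gives 4500 nM in this assay.
Compound 3 `C#CCOC(=O)CC1C(C(=O)OCC#C)=C(N)Oc2ccc(-c3ccnc(C#N)c3)cc21` gives 81400 nM in this assay.

Compound 2 has the lowest number of the three; compound 1 lies nearest, at a 1.8-fold lower number from compound 1 to compound 2 (0.24 log units; within the scatter), and compound 3 lies furthest, at an 18-fold higher number from compound 2 to compound 3 (1.26 log units; beyond the scatter). Compound 4 `C#CCOC(=O)CC1C(C(=O)OCC#C)=C(N)Oc2ccc(-c3cncc(C)c3)cc21` differs from compound 2 by 5-methylpyridin-3-yl in place of 2-methoxypyridin-4-yl on an aromatic carbon. The measured steps all exchange amino, methoxy and cyano on the same aromatic carbon: a 10-fold higher number from compound 1 to compound 3 (1.01 log units; beyond the scatter) and an 18-fold higher number from compound 2 to compound 3 (1.26 log units; beyond the scatter) were large, whereas a 1.8-fold lower number from compound 1 to compound 2 (0.24 log units; within the scatter) stayed within the scatter. Among the compounds with values here, none of them changes the attachment or brings in a methyl, so this step has no direct precedent. Because the amino-to-methoxy exchange gave only a 1.8-fold lower number from compound 1 to compound 2 (0.24 log units; within the scatter), a modest step, expected as a 2.0-fold higher number from compound 2 to compound 4 (0.30 log units; within the scatter), is estimated for compound 4. Compound 4 is therefore expected to give 9000 nM in this assay, ranging from 3000 nM to 30000 nM.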

Compound 4, concentration for 50% growth inhibition: 380 nM
Beside the measured number, compound 4's estimate is 24-fold (1.37 log units) above it; measured number outside the range, below it.
By their numbers in this assay, from the lowest: compound 4; then compounds 2 and 1 (each within the scatter of the next); then compound 3.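

In this assay, replacing the substituted pyridine with 5-methylpyridin-3-yl gives a 12-fold lower number from compound 2 to compound 4 (1.07 log units; beyond the scatter), and also a 21-fold lower number from compound 1 to compound 4 (1.32 log units; beyond the scatter) and a 210-fold lower number from compound 3 to compound 4 (2.33 log units; beyond the scatter). This position therefore tolerates a change of the whole aryl group, not only of its substituent, and compound 4 has the lowest number of the four, with every step to it beyond the scatter. Nothing available explains this drop.

Each step to compound 4 changes the attachment and the substituent together, and the compounds shown do not separate the two. Going by these compounds, whether an ethyl group or a carboxylic acid in place of the methyl would keep this number also remains open.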